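Swapping the aromatic tail: from compound 3 to compound 4

The compounds below may be only part of what the source reports. "The series", "measured", "known", "first", "only" and "open" are said of these compounds alone.

Measured so far, in a functional assay on the whole organism (blood) with Rattus norvegicus as the target, with stated times of 24 h and 1 h, at a dose of 5 mg/kg by the intraperitoneal route; on this read-out lower numbers stand for a weaker effect and higher numbers for a stronger effect at the one dose given:
Compound 1, `Cc1cccc(C(=O)NCCC2CCN(S(=O)(=O)NC(=O)NC[C@@H]3C[C@@H]4C=C[C@@H]3C4)CC2)n1`, gives 20%.
Compound 2, `Cc1ncccc1C(=O)NCCC1CCN(S(=O)(=O)NC(=O)NC[C@@H]2C[C@@H]3C=C[C@@H]2C3)CC1`, gives 16%.
Compound 3, `COc1ccc2nccc(C(=O)NCCC3CCN(S(=O)(=O)NC(=O)NC[C@@H]4C[C@@H]5C=C[C@@H]4C5)CC3)c2c1`, gives 10%.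

Compound 3 holds the lowest of the three numbers, but its gaps to the others are small: a number 6 percentage points lower from compound 2 to compound 3 (within the scatter) and a number 10 percentage points lower from compound 1 to compound 3 (within the scatter), both within the scatter, so the three compounds cannot be ranked against each other.

Compound 4, `O=C(NC[C@@H]1C[C@@H]2C=C[C@@H]1C2)NS(=O)(=O)N1CCC(CCNC(=O)c2cccc3c2OCCO3)CC1`, differs from compound 3 in one place: 2,3-dihydro-1,4-benzodioxin-5-yl in place of 6-methoxyquinolin-4-yl on a carbonyl carbon. The three measured steps all exchange the aromatic group on the same carbonyl carbon, and none moved the read-out beyond the scatter: a number 4 percentage points lower from compound 1 to compound 2 (within the scatter), a number 10 percentage points lower from compound 1 to compound 3 (within the scatter), a number 6 percentage points lower from compound 2 to compound 3 (within the scatter). The step to compound 4 is the same kind of exchange, so in this assay no change beyond the scatter is expected; the expected step is a number 4 percentage points higher from compound 3 to compound 4 (within the scatter). Compound 4 is therefore estimated at 14%, with a range from 4% to 26%.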

Compound 4, a percentage reported as activity, at one dose (the size of the read-out at that dose, not a potency): 11%
Compound 4: middle estimate off by 3 percentage points, on the high side; low and high end bracket the measured number.
By their numbers in this assay, from the lowest: compounds 3, 4, 2 and 1 (each within the scatter of the next).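

Compound 4 is the only one of the four whose tail holds no ring nitrogen: its 2,3-dihydro-1,4-benzodioxin-5-yl group has oxygen as its only hetero atom and includes a non-aromatic ring. In this assay, this exchange stays within the scatter against all three earlier tails (a number 1 percentage points higher from compound 3 to compound 4 (within the scatter); a number 5 percentage points lower from compound 2 to compound 4 (within the scatter); a number 9 percentage points lower from compound 1 to compound 4 (within the scatter)), so among these four compounds, a ring nitrogen in the group on this carbonyl carbon is not needed for a read-out of this size. Nothing available explains why the read-out stays so flat across these tails.

Every tail shown still attaches through an aromatic ring, so a cyclohexyl group on this carbonyl carbon remains untested here. Also open, from the compounds shown here alone, is whether a tail carrying a carboxylic acid or an amine would move the read-out beyond the scatter.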